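Removing the methyl group from compound 1

A few compounds are considered here, and "the series" means these few. Any claim that something is new, unique, unknown or untested is made for them only; others in the source may bear on it.

Measured so far in a functional assay on MDA-MB-231 cells (Homo sapiens) for antiproliferative activity, read by sulforhodamine B assay, with a stated time of 48 h; a higher number here means a weaker inhibitor, a lower number a stronger inhibitor:
- compound 1 `COc1ccc2nc(-c3ccc(N/C=C\C(=O)c4ccc(OC)c(O)c4)c(C)c3)sc2c1`: 14000 nM
- compound 2 `COc1cc(OC)c2sc(-c3ccc(N/C=C\C(=O)c4ccc(OC)c([N+](=O)[O-])c4)cc3)nc2c1`: 12900 nM

Compound 1 and compound 2 lie within the scatter of each other, so neither ranks ahead. Compound 3 `COc1ccc2nc(-c3ccc(N/C=C\C(=O)c4ccc(OC)c(O)c4)cc3)sc2c1` is not yet measured and has hydrogen in place of methyl on an aromatic carbon. For the measured compounds named here, the measured pair offers no single-change step to size this one. In this assay, a small step is expected, probably none beyond the scatter, with a slight lean towards a lower number. The estimated step runs a 1.4-fold lower number from compound 1 to compound 3 (0.15 log units; within the scatter). For compound 3 the expected value is 10000 nM. The expected range for compound 3 is 3500 nM to 25000 nM.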

Compound 3, half-maximal inhibitory concentration: 18900 nM
For compound 3 the middle estimate is 1.9-fold (0.28 log units) below the measured one; measured number inside the range.
By their numbers in this assay, from the lowest: compounds 2, 1 and 3 (each within the scatter of the next).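

Hydrogen in place of methyl on this aromatic carbon gives a 1.4-fold higher number from compound 1 to compound 3 (0.13 log units; within the scatter) in this assay as the first single-change step in the series. At this position, ortho to a large group and meta to a large group, the methyl group therefore makes no difference beyond the scatter. No measurement bears on the reason for this result.

Going by these compounds, whether an ethyl group, a chlorine atom or an amine at this carbon would also stay within the scatter remains open. Also open, on these data alone, is whether the same step would hold with a different substitution pattern elsewhere on the core.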